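A Chloro-to-Bromo Swap Awaiting Its Number

The source may report more compounds than this note shows. Statements on the series, on what has been measured and on what is new or still open speak of the compounds shown alone.

Compound 1 `COC(=O)c1c(Cl)cc(Cl)cc1OC(=O)COc1cc(O)c2c(=O)cc(-c3ccccc3)oc2c1` gives 43600 nM in a functional assay on cells (T-cell, Mus musculus, strain BALB/c) for inhibition, read by MTT assay, with a stated time of 72 h; on this read-out lower numbers stand for stronger inhibition and higher numbers for weaker inhibition.
Compound 2 `COC(=O)c1cccc(OC)c1OC(=O)COc1cc(O)c2c(=O)cc(-c3ccccc3)oc2c1` gives 36800 nM in this assay.
Compound 3 `COC(=O)c1ccc(Cl)cc1OC(=O)COc1cc(O)c2c(=O)cc(-c3ccccc3)oc2c1` gives 12400 nM in this assay.

Of these three, compound 3 has the lowest number, which on this read-out means the strongest inhibition; compound 2 is its nearest neighbour and compound 1 is furthest away, both beyond the scatter. Among the compounds with values here, only one single-point step is known among them: a 3.5-fold lower number from compound 1 to compound 3 (0.55 log units; beyond the scatter). That step removed a chloro group and gave a modest improvement.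

Compound 4 `COC(=O)c1ccc(Br)cc1OC(=O)COc1cc(O)c2c(=O)cc(-c3ccccc3)oc2c1` is the next candidate. It differs from compound 3 by bromo in place of chloro on an aromatic carbon. Within the data shown here, no measured step in this set exchanges one halogen for another, and the single known step concerns removal of a chloro group elsewhere on the same ring rather than its replacement. There is therefore no direct evidence for a shift in either direction, and a step within the scatter is the plainest expectation. Compound 4 is expected to give about 12000 nM, with a likely range from 5000 nM to 30000 nM. The step this estimate implies, a 1.0-fold lower number from compound 3 to compound 4 (0.01 log units; within the scatter), is expected to remain within the usual scatter.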

Compound 4, half-maximal inhibitory concentration: 17600 nM
Compound 4: middle estimate off by 1.5-fold (0.17 log units), on the low side; the range from low to high includes it.
By their numbers in this assay, from the lowest: compounds 3 and 4 (each within the scatter of the next); then compounds 2 and 1 (each within the scatter of the next).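

At this position, para to a methoxycarbonyl group, bromo in place of chloro gives a 1.4-fold higher number from compound 3 to compound 4 (0.15 log units; within the scatter) in this assay, so this pair shows no real difference between the two halogens. This is the first exchange of one halogen for another among the compounds shown, whereas the earlier single-point step, a 3.5-fold lower number from compound 1 to compound 3 (0.55 log units; beyond the scatter), came from removing a chloro group, so this position tolerates the swap without a measurable change. No outside measurement bears on why the two halogens read alike here.

The compounds leave open whether a different kind of group at this position, such as an amine, a nitrile or a carboxylic acid, would shift the number beyond the scatter. They also leave open how a fluoro group or plain hydrogen would compare here.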